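Substituent swap on the alcohol-bearing aryl ring

The compounds below may be only part of what the source reports. "The series", "measured", "known", "first", "only" and "open" are said of these compounds alone.

Compounds measured so far:
compound 1 `CSc1ccc(COCC#CC(O)c2ccc(F)cc2)cc1`: 12000 nM
compound 2 `COc1ccc(C(O)C#CCOCc2ccc(SC)cc2)cc1`: > 100000 nM

In an assay on isolated protein for inhibition of Polyunsaturated fatty acid 5-lipoxygenase (Homo sapiens) (a higher number here means a weaker inhibitor, a lower number a stronger inhibitor), compound 1 gives 12000 nM. Compound 2 reaches only the limit of the assay, > 100000 nM, so for compound 2 there is no number, only (the limit of > 100000 nM in this assay, at which 1 of the 2 values shown sits). Going by the values given here, the single measured step, an at least 8.3-fold higher number from compound 1 to compound 2 (0.92 log units; beyond the scatter), is therefore itself bounded on one side.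

Compound 3 `CSc1ccc(COCC#CC(O)c2ccc(C#N)cc2)cc1` is the next member, differing from compound 2 by cyano in place of methoxy on an aromatic carbon; the leaving group carried an oxygen, the entering group brings one triple bond outside aromatic rings. Among the compounds with values here, no measured step involves a cyano group, so the only bearing comes from the fluoro-to-methoxy step, which placed the methoxy compound at the limit while the fluoro compound gave a number. Within the data shown here, because cyano is a third group with no measured counterpart, direction is open. Compound 3 is expected to give 40000 nM, between 10000 nM and 160000 nM, an estimated step of an at least 2.5-fold lower number from compound 2 to compound 3 (0.39 log units; beyond the scatter).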

Compound 3, half-maximal inhibitory concentration: 41000 nM
Compound 3: the middle estimate sits 1.0-fold (0.01 log units) below what was measured; measured number inside the range.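

In this assay, cyano in place of methoxy on this aromatic carbon, para to a large group, returns a measurable value where compound 2 has only a limit, so an at least 2.4-fold lower number from compound 2 to compound 3 (0.38 log units; beyond the scatter) is a step bounded on one side only: the limit of > 100000 nM in this assay, at which 1 of the 3 values shown sits.

Cyano does not match fluoro at this position, with a 3.4-fold higher number from compound 1 to compound 3 (0.53 log units; beyond the scatter), so the three groups now read in the order fluoro, cyano, methoxy, and compound 1 remains the strongest inhibitor of the three, all of its steps being beyond the scatter. Methoxy and cyano have equal counts of heavy atoms and of hydrogen-bond acceptors, yet compound 2 and compound 3 still differ, so these counts alone do not separate the groups at this position.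

From the compounds shown here alone, the true distance between compound 2 and compound 3 stays unknown, and so does the reading of chloro, trifluoromethyl or an amine on this aromatic carbon relative to fluoro. Also open, going by these compounds, is whether the order of the three groups holds with another group in place of the methylthio group on the other ring.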